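A few compounds are considered here, and "the series" means these few. Any claim that something is new, unique, unknown or untested is made for them only; others in the source may bear on it.

Compound 2 `CCCC[C@@H]1O[C@H](COCc2ccccc2)[C@@H](OCc2ccccc2)[C@H](OCc2ccccc2)[C@H]1O` was examined in a functional assay on HL-60 cells (Homo sapiens) for antiproliferative activity, read by MTT assay; a lower number here means a stronger inhibitor, a higher number a weaker inhibitor; there compound 2 was recorded as "not active" (no number reported), so no single number places it among the others. Compound 3 `CCC[C@@H]1O[C@H](COC)[C@@H](OC)[C@H](OC)[C@H]1O`, whose ether groups are methyl rather than benzyl, was likewise recorded in this assay as "not active" (no number reported), and only compound 1 `O[C@@H]1[C@@H](OCc2ccccc2)[C@H](O)[C@@H](COCc2ccccc2)O[C@H]1Cc1ccccc1` gave a number, with compound 1 at 35300 nM in this assay. Against this background stands compound 4 `CCC[C@@H]1O[C@H](COCc2ccccc2)[C@@H](OCc2ccccc2)[C@H](OCc2ccccc2)[C@H]1O`, which differs from compound 2 by hydrogen in place of methyl on a saturated chain carbon, three bonds along the chain from a saturated ring carbon. With compound 2 already without a number, and compound 3 carrying the same propyl chain and also without one, a change of this size is expected to move the readout little if at all, with no direction favoured. Compound 4 is therefore estimated to lie near 60000 nM, within 15000 nM to 250000 nM, and is quite likely to be reported without a number at all.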

Compound 4, half-maximal inhibitory concentration: 11700 nM
Estimate against measurement, compound 4: 5.1-fold (0.71 log units) above, and the stated range ends above it.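

Within the data shown here, compound 2 has no number in this assay, so no step to compound 4 can be read. The compounds shown leave open how the butyl-to-propyl change affects activity. No evidence shown bears on this result.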